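The compounds below may be only part of what the source reports. "The series", "measured", "known", "first", "only" and "open" are said of these compounds alone.

Measured compounds:
compound 1, `N#Cc1cccc(-c2cnc(C(=O)CCCCCCc3ccccc3)o2)c1`, 15 nM
compound 2, `O=C(O)c1ccc(-c2cnc(C(=O)CCCCCCc3ccccc3)o2)cc1`, 60 nM
compound 3, `COc1ccnc(-c2cnc(C(=O)CCCCCCc3ccccc3)o2)c1`, 0.8 nM

Compound 3 holds the lowest number of the three in an assay (Rattus norvegicus) for inhibition of Fatty-acid amide hydrolase 1 (Homo sapiens); a lower number here means a stronger inhibitor, a higher number a weaker inhibitor. Its nearest neighbour is compound 1, with a 19-fold lower number from compound 1 to compound 3 (1.27 log units; beyond the scatter); compound 2 lies furthest, with a 75-fold lower number from compound 2 to compound 3 (1.88 log units; beyond the scatter). Both steps are beyond the scatter and both end at the 4-methoxypyridin-2-yl of compound 3.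

Compound 4, `CN1CCN(C(=O)c2cnc(C(=O)CCCCCCc3ccccc3)o2)CC1`, differs from compound 3 in one place: (4-methylpiperazin-1-yl)carbonyl in place of 4-methoxypyridin-2-yl on an aromatic carbon. Among the measured compounds shown here, the two steps into compound 3 bear on this only in part: they show that exchanging one six-membered aromatic group for another at this position moves the number a great deal, but no measured compound carries a non-aromatic carbonyl-linked group there. Because both a 19-fold lower number from compound 1 to compound 3 (1.27 log units; beyond the scatter) and a 75-fold lower number from compound 2 to compound 3 (1.88 log units; beyond the scatter) run downward toward compound 3, leaving compound 3 for a wholly different group is expected to give a higher number in this assay, and the step is expected to be large, a 190-fold higher number from compound 3 to compound 4 (2.27 log units; beyond the scatter), though with wide uncertainty.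

For compound 4 the expected value in this assay is 150 nM, in a range from 20 nM to 1500 nM.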

Compound 4, inhibition constant: 80 nM
Compound 4: the middle estimate sits 1.9-fold (0.27 log units) above what was measured, within the range that was stated.
By their numbers in this assay, from the lowest: compound 3; then compound 1; then compounds 2 and 4 (each within the scatter of the next).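

In this assay, exchanging the aromatic group for a non-aromatic ring linked through a carbonyl gives a 100-fold higher number from compound 3 to compound 4 (2.00 log units; beyond the scatter), the first view of this kind of group at this aromatic carbon. Against the other two aromatic groups, the same exchange gives a 5.3-fold higher number from compound 1 to compound 4 (0.73 log units; beyond the scatter) and a 1.3-fold higher number from compound 2 to compound 4 (0.12 log units; within the scatter), so (4-methylpiperazin-1-yl)carbonyl and 4-carboxyphenyl cannot be told apart here despite their different rings. An aromatic ring at this place therefore does not by itself bring a low number: compound 2 carries one and still matches compound 4, and the number of compound 3 stands out from all three.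

From the compounds shown here alone, it remains open whether the carbonyl link or the piperazine ring sets the number of compound 4. A morpholine amide, a simple dimethylamide or an unsubstituted pyridin-2-yl at this carbon would help separate these parts. No evidence at hand explains these steps.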